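Removing the methoxy group from compound 1's benzoate ester

The source may report more compounds than this note shows. Statements on the series, on what has been measured and on what is new or still open speak of the compounds shown alone.

In a functional assay on SK-LU-1 cells (Homo sapiens) for antiproliferative activity, read by sulforhodamine B assay, with a stated time of 48 h, tested at 50 uM (on this read-out higher numbers stand for more inhibition at the one concentration tested (going by the name of the read-out) and lower numbers for less inhibition), compound 1 `COc1cccc(C(=O)Oc2cc3c(cc2C)[C@@H](C(C)C)CC=C3C)c1` gives 24.2% and stands lowest of the three measured values. Within the data shown here, compound 3 `Cc1cc2c(C(C)C)ccc(C)c2cc1OC(=O)c1ccc(C(F)(F)F)cc1` gives 28.7%, within the scatter of compound 1, while compound 2 `CC1=CC[C@H](C(C)C)c2cc(C)c(OC(=O)c3ccc([N+](=O)[O-])cc3)cc21` gives 47.5%, the only value beyond it; the one measured step, a number 23.3 percentage points higher from compound 1 to compound 2 (beyond the scatter), came with 4-nitrophenyl in place of 3-methoxyphenyl on a carbonyl carbon. Compound 4 `CC1=CC[C@H](C(C)C)c2cc(C)c(OC(=O)c3ccccc3)cc21` differs from compound 1 by hydrogen in place of methoxy on an aromatic carbon. Among the measured compounds shown here, no measured step removes a methoxy group, and the step from compound 1 to compound 2 concerns a different replacement on the same ring, so it gives no guide to direction. Compound 4 is therefore expected to show a number 1.8 percentage points higher from compound 1 to compound 4 (within the scatter), a change within the scatter. Compound 4 is estimated at 26%, between 13% and 40%.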

Compound 4, a percentage reported as inhibition, at one concentration (the size of the read-out at that concentration, not a potency): 37%
Beside the measured number, compound 4's estimate is 11 percentage points below it; measured number inside the range.
By their numbers in this assay, from the lowest: compounds 1, 3 and 4 (each within the scatter of the next, the first and the last beyond it); then compound 2.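

In this assay, among these compounds, the unsubstituted benzoate proves a distinct reference point on this ring: removing the methoxy group gives a number 12.8 percentage points higher from compound 1 to compound 4 (beyond the scatter) and so this change is not silent, contrary to what the earlier compounds left possible. Hydrogen in place of nitro gives a number 10.5 percentage points lower from compound 2 to compound 4 (beyond the scatter) and thus places compound 4 apart from both substituted esters, with the two groups moving the number in opposite directions. Nothing available accounts for either step.

As far as these compounds go, whether an amine or a carboxylic acid on this ring would lower the number, as methoxy does, or raise it, as nitro does, remains open.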